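Aryl enone acids: ethyl in place of tert-butyl

A few compounds are considered here, and "the series" means these few. Any claim that something is new, unique, unknown or untested is made for them only; others in the source may bear on it.

Measured so far:
Compound 1, `CCc1cc(CC)c(C(=O)/C=C/C(=O)O)c(CC)c1`: 7280 nM
Compound 2, `CC(C)(C)c1ccc(C(=O)/C=C/C(=O)O)cc1`: 8740 nM

Both compounds were read in a functional assay on LS174T cells (Homo sapiens) for inhibition, read by MTT assay, with a stated time of 72 h; a lower number here means a stronger inhibitor, a higher number a weaker inhibitor. Compound 2 and compound 1 give numbers that lie within the usual scatter of each other, so on these data compound 2 cannot be told apart from compound 1; both are weak inhibitors in this assay.

Compound 3, `CCc1ccc(C(=O)/C=C/C(=O)O)cc1`, has not yet been measured in this assay. It differs from compound 2 by one change: ethyl in place of tert-butyl on an aromatic carbon. Among the measured compounds shown here, no measured pair shows this change, so its size is not known from the data. For the measured compounds named here, with only two weak compounds in hand and no step to go on, the expectation is a step of little or no size beyond the scatter, with no clear direction.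

Compound 3 is therefore expected to give about 10000 nM in this assay, within a range of 4000 nM to 25000 nM, which is an expected step of a 1.1-fold higher number from compound 2 to compound 3 (0.06 log units; within the scatter).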

Compound 3, half-maximal inhibitory concentration: 21000 nM
For compound 3 the middle estimate is 2.1-fold (0.32 log units) below the measured one, within the range that was stated.
By their numbers in this assay, from the lowest: compounds 1 and 2 (each within the scatter of the next); then compound 3.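

In this assay the substituent on this aromatic carbon, para to a group of 7 heavy atoms, makes a readable difference: ethyl in place of tert-butyl gives a 2.4-fold higher number from compound 2 to compound 3 (0.38 log units; beyond the scatter), a modest step but the first in the series beyond the scatter. The direction is toward weaker inhibition, so the smaller of these two alkyl groups is the poorer one here, though a single pair sets no trend with group size. Nothing measured on these compounds speaks to what lies behind the step.

Open, from the compounds shown here alone, is whether an amine or a longer chain on this aromatic carbon would give a lower or a higher number than tert-butyl. Also open, going by these compounds, is whether the same exchange would give a step of similar size on a differently substituted core, such as that of compound 1.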